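Replacing a Ring Substituent in a B1 Receptor Binder

The source may hold more compounds than are shown below. What is called first, only, known or untested is meant among the compounds shown, and "the series" means these compounds.

Of the compounds shown here, three have been measured in an assay on HEK293 cells for displacement of a labelled ligand from B1 bradykinin receptor (Homo sapiens), read by scintillation counting; a lower number here means a stronger inhibitor, a higher number a weaker inhibitor. Compound 1 `COc1ccc(S(=O)(=O)N(C)CCOCC(=O)N(C)Cc2ccc(C3=NCCN3)cc2)c(C)c1` gives 5.5 nM, and compound 2 `Cc1c(Cl)ccc(S(=O)(=O)N(C)CCOCC(=O)N(C)Cc2ccc(C3=NCCN3)cc2)c1Cl` gives 2.1 nM. Between them stands one step: a 2.6-fold lower number from compound 1 to compound 2 (0.42 log units; beyond the scatter). Compound 3 `COc1cc(C)c(S(=O)(=O)N(C)CCOCC(=O)N2CCC(C3CCN(C)CC3)CC2)c(C)c1` gives 0.7 nM, the lowest of the three numbers, its gaps to compound 2 and to compound 1 both beyond the scatter. Compound 4 `COc1cc(C)c(S(=O)(=O)N(C)CCOCC(=O)N2CCC(C(C)(C)CN(C)C)CC2)c(C)c1` differs from compound 3 in one place: 1-((dimethylamino)methyl)-1-methylethyl in place of 1-methylpiperidin-4-yl on a saturated ring carbon. For the measured compounds named here, the only measured step changes the group on the sulfonyl sulfur, not this position, so no measured step bears on this change. With nothing pointing either way, compound 4 is expected to stay close to compound 3, the expected step being a 2.1-fold higher number from compound 3 to compound 4 (0.33 log units; beyond the scatter). The estimate for compound 4 in this assay is 1.5 nM, with a range from 0.4 nM to 6 nM.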

Compound 4, inhibition constant: 10 nM
Estimate against measurement, compound 4: 6.7-fold (0.82 log units) below; the measured number lies above the stated range.
By their numbers in this assay, from the lowest: compound 3; then compound 2; then compounds 1 and 4 (each within the scatter of the next).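

In this assay, the step is large: a 14-fold higher number from compound 3 to compound 4 (1.15 log units; beyond the scatter). The group that leaves and the group that enters have the same heavy atoms and the same hydrogen-bond counts, and differ in that one has a ring and the other has none, so this position on the saturated ring responds strongly to a change that leaves those counts untouched. Nothing available gives a cause for this step.

The compounds shown leave open whether a different ring, such as 1-methylpiperazin-4-yl, would keep the number near that of compound 3. They also leave open how an open chain without the two extra methyl groups, such as 2-(dimethylamino)ethyl, would behave.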